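Widening the oxygen ring on the amide carbonyl

The source may hold more compounds than are shown below. What is called first, only, known or untested is meant among the compounds shown, and "the series" means these compounds.

Of the compounds shown here, three sharing one core have been measured in an assay on HEK293 cells for positive allosteric modulation of metabotropic glutamate receptor 5 (Homo sapiens), read by FLIPR, with a stated time of 1 h; on this read-out lower numbers stand for an effect already at smaller amounts and higher numbers for an effect only at larger amounts of compound. Compound 1 `CC1CC1C(=O)N1CCc2nc(C#Cc3ccccc3)sc2C1` gives 9.4 nM, compound 2 `O=C(C1CC(F)C1)N1CCc2nc(C#Cc3ccccc3)sc2C1` gives 85 nM, and compound 3 `O=C(C1CCCO1)N1CCc2nc(C#Cc3ccccc3)sc2C1` gives 790 nM. Compound 3 thus stands at the highest number of the three: the change from compound 1 brought an 84-fold higher number from compound 1 to compound 3 (1.92 log units; beyond the scatter), and the change from compound 2 brought a 9.3-fold higher number from compound 2 to compound 3 (0.97 log units; beyond the scatter). Compound 4 `O=C(C1CCCCO1)N1CCc2nc(C#Cc3ccccc3)sc2C1` differs from compound 3 in one place: oxan-2-yl in place of oxolan-2-yl on a carbonyl carbon. Among the compounds with values here, no measured step exchanges one oxygen-containing ring for a wider one, so none bears directly on this change. The steps that end at compound 3 only show that the groups on the carbonyl carbon in compound 1 and compound 2 gave lower numbers than the oxolan-2-yl group, and nothing shows whether widening that ring moves the number up or down. The expectation for compound 4 in this assay is therefore a step of a 1.1-fold higher number from compound 3 to compound 4 (0.06 log units; within the scatter), which lies within the scatter. Compound 4 is estimated in this assay at 900 nM, with a range from 250 nM to 3500 nM.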

Compound 4, half-maximal effective concentration: 320 nM
Compound 4: the middle estimate sits 2.8-fold (0.45 log units) above what was measured; the range from low to high includes it.
By their numbers in this assay, from the lowest: compound 1; then compound 2; then compound 4; then compound 3.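

In this assay, within the data shown here, this is the first step that changes only the size of an oxygen-containing ring on this carbonyl carbon, and oxan-2-yl in place of oxolan-2-yl gives a 2.5-fold lower number from compound 3 to compound 4 (0.39 log units; beyond the scatter). The step is modest but beyond the scatter, so the size of the ring does count at this position, and the six-membered ring gives the lower number of the two. Even so, the wider ring leaves a clear gap to the two groups without oxygen, with a 3.8-fold higher number from compound 2 to compound 4 (0.58 log units; beyond the scatter) and a 34-fold higher number from compound 1 to compound 4 (1.53 log units; beyond the scatter), so the 3-fluorocyclobutyl and 2-methylcyclopropyl groups still give the lower numbers, and nothing available gives a reason for any of these steps.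

On these data alone, what remains open is whether the ring oxygen itself goes with the higher numbers, a question that a plain cyclopentyl or cyclohexyl group on this carbonyl carbon would address directly. Also open, as far as these compounds go, is how an oxan-4-yl group, or a piperidine ring carrying an amine nitrogen, would compare with the oxan-2-yl group.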